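The compounds below may be only part of what the source reports. "The series", "measured", "known", "first", "only" and "open" are said of these compounds alone.

Of the compounds shown here, three built on one shared core have been measured in a functional assay on DU-145 cells (Homo sapiens) for inhibition, read by trypan blue exclusion, with a stated time of 96 h; on this read-out higher numbers stand for weaker inhibition of growth and lower numbers for stronger inhibition of growth. Compound 1 `Cc1ccc(S(=O)(=O)/C(=C/c2ccccc2OCc2ccccc2)C(=O)c2ccc(Br)cc2)cc1` gives 1000 nM in this assay. Compound 3 `COc1ccccc1/C=C(\C(=O)c1ccc(Br)cc1)S(=O)(=O)c1ccc(C)cc1` gives 1000 nM in this assay, and the step of no change at the digits printed from compound 1 to compound 3 (within the scatter) leaves the number where it was. Compound 2 `CN(C)c1ccc(/C=C(\C(=O)c2ccc(Br)cc2)S(=O)(=O)Cc2ccc(F)cc2)cc1`, which carries a 4-fluorobenzyl on the sulfonyl sulfur and differs from the others in its second aromatic ring as well, gives 50000 nM in this assay. On these numbers compound 3 stands level with compound 1, the two together being the lowest, while compound 2 lies furthest from it with a higher number.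

Compound 4 `COc1ccccc1/C=C(\C(=O)c1ccc(Br)cc1)S(=O)(=O)Cc1ccc(F)cc1` has not yet been measured. It differs from compound 3 in one place: 4-fluorobenzyl in place of 4-methylphenyl on a sulfonyl sulfur. Among the compounds with values here, no measured step changes this group alone, so none bears directly on it. Within the data shown here, compound 2, the one measured compound with a 4-fluorobenzyl on the sulfonyl sulfur, gives a higher number than compound 3, yet it also differs elsewhere, so its value is only a loose hint. A weakening of growth inhibition is therefore expected, and compound 4 is estimated at 5000 nM in this assay, within 1000 nM to 40000 nM. The expected step is a 5.0-fold higher number from compound 3 to compound 4 (0.70 log units; beyond the scatter).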

Compound 4, concentration for 50% growth inhibition: 25000 nM
Estimate against measurement, compound 4: 5.0-fold (0.70 log units) below; measured number inside the range.
By their numbers in this assay, from the lowest: compounds 1 and 3 (each within the scatter of the next); then compounds 4 and 2 (each within the scatter of the next).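

Within the data shown here, compound 3 and compound 4 differ only in the group on the sulfonyl sulfur, and that single change gives a 25-fold higher number from compound 3 to compound 4 (1.40 log units; beyond the scatter), meaning much weaker inhibition of growth; this is the first sign that 4-fluorobenzyl is far less well tolerated here than 4-methylphenyl. With 4-fluorobenzyl in place, changing the other aromatic ring gives a 2.0-fold lower number from compound 2 to compound 4 (0.30 log units; within the scatter), a step within the scatter, so that pair cannot be told apart. Nothing available explains why the group on the sulfur matters so much.

The change replaces a methyl-bearing ring with a fluorine-bearing benzyl, so these compounds cannot show which part of it carries the loss. A comparison with 4-fluorophenyl or 4-methylbenzyl on the sulfur would separate the two parts.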